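Amide-substituted piperazine series: fluoro to methoxy on outer ring

This account rests on a few compounds, and the source may have more. Where it says the series, first, only, none or still open, it means among the compounds named here.

Compound 1 `Cc1cccc(NC(=O)N2CCN(c3nc(N)nc4sc(-c5ccc(F)cc5)nc34)CC2)c1`: in a functional assay on cells (Lymphocyte, Homo sapiens) (on this read-out higher numbers stand for weaker inhibition and lower numbers for stronger inhibition), compound 1 gives 300 nM.
Compound 2 `Nc1nc(N2CCN(C(=O)COc3ccc(F)cc3)CC2)c2nc(-c3ccc(F)cc3)sc2n1`: in this assay compound 2 gives 70 nM.

Among the compounds with values here, compound 2 holds the lower of the two numbers so far; its only neighbour is compound 1, and the single measured step, a 4.3-fold lower number from compound 1 to compound 2 (0.63 log units; beyond the scatter), separates them. That step exchanges the whole group on the carbonyl carbon and does not touch a substituent on the outer ring.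

Compound 3 `COc1ccc(OCC(=O)N2CCN(c3nc(N)nc4sc(-c5ccc(F)cc5)nc34)CC2)cc1` differs from compound 2 by methoxy in place of fluoro on an aromatic carbon, read one bond further out as 4-fluorophenoxy to 4-methoxyphenoxy. Within the data shown here, no measured step bears on a change at this place, so nothing in the data supports a movement beyond the scatter in either direction. The step from compound 2 to compound 3 is therefore expected to be small, a 1.2-fold higher number from compound 2 to compound 3 (0.08 log units; within the scatter), within the scatter. For compound 3 the estimated value in this assay is 85 nM, with an expected range from 30 nM to 250 nM.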

Compound 3, half-maximal inhibitory concentration: 40 nM
Beside the measured number, compound 3's estimate is 2.1-fold (0.33 log units) above it; the measured number falls inside the stated range.
By their numbers in this assay, from the lowest: compounds 3 and 2 (each within the scatter of the next); then compound 1.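

Notes on the outer ring: in this assay this is the first measured change at this place on the phenoxy ring, and methoxy in place of fluoro gives a 1.8-fold lower number from compound 2 to compound 3 (0.24 log units; within the scatter), so the exchange of one heavy atom for two, with one hydrogen-bond acceptor added, leaves the number within the scatter. The carbonyl-carbon exchange also holds with the new ring substituent: (4-methoxyphenoxy)methyl in place of (3-methylphenyl)amino gives a 7.5-fold lower number from compound 1 to compound 3 (0.88 log units; beyond the scatter), again beyond the scatter, as with the fluoro member (a 4.3-fold lower number from compound 1 to compound 2 (0.63 log units; beyond the scatter)). Nothing available explains these numbers.

On these data alone, with only fluoro and methoxy at this place, it remains open how far the position tolerates other groups, such as an amine or a carboxylic acid. Also open, as far as these compounds go, is whether a longer chain between the carbonyl and the ring oxygen keeps the numbers of compound 2 and compound 3.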